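Amide side chain series: fluoro to methoxy

The compounds below may be only part of what the source reports. "The series", "measured", "known", "first", "only" and "open" are said of these compounds alone.

Compound 1 `O=C(Nc1ccccc1)c1c([N+](=O)[O-])noc1-c1ccc(Cl)cc1Cl`: 67300 nM
Compound 2 `O=C(NCc1ccc(F)cc1)c1c([N+](=O)[O-])noc1-c1ccc(Cl)cc1Cl`: 86400 nM

In an ADME assay on J774.A1 cells (Mus musculus) for cytotoxicity, read by MTT assay, with a stated time of 48 h (on this read-out higher numbers stand for lower toxicity in this test and lower numbers for higher toxicity in this test), compound 2, at 86400 nM, lies within the scatter of compound 1. Compound 3 `COc1ccc(CNC(=O)c2c([N+](=O)[O-])noc2-c2ccc(Cl)cc2Cl)cc1` has methoxy in place of fluoro on an aromatic carbon, para to a large group: methoxy in place of fluoro on an aromatic carbon. Among the compounds with values here, the only measured step, a 1.3-fold higher number from compound 1 to compound 2 (0.11 log units; within the scatter), also falls in the group on the amide nitrogen, and no measured step shows a change beyond the scatter. The expected result is no change beyond the scatter, with an estimated step of a 1.2-fold lower number from compound 2 to compound 3 (0.06 log units; within the scatter). Compound 3 is expected at 75000 nM, with an estimated range of 35000 nM to 150000 nM.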

Compound 3, half-maximal cytotoxic concentration: 80500 nM
For compound 3 the middle estimate is 1.1-fold (0.03 log units) below the measured one, and the stated range covers the measured number.
By their numbers in this assay, from the lowest: compounds 1, 3 and 2 (each within the scatter of the next).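

In this assay, within the data shown here, methoxy in place of fluoro on an aromatic carbon, para to a large group, gives a 1.1-fold lower number from compound 2 to compound 3 (0.03 log units; within the scatter), the first reading at this position, and it stays within the scatter. 4-Methoxybenzyl in place of phenyl on the amide nitrogen gives a 1.2-fold higher number from compound 1 to compound 3 (0.08 log units; within the scatter), so this second benzyl side chain also stays within the scatter of the phenyl amide. No supporting evidence bears on these results. Still open, as far as these compounds go, is whether an amine or a carboxylic acid at this aromatic carbon, or a longer chain on the amide nitrogen, would produce a step beyond the scatter.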